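Replacing 1-methyl-1-phenylethyl in compound 1

The source may hold more compounds than are shown below. What is called first, only, known or untested is meant among the compounds shown, and "the series" means these compounds.

Among the measured compounds shown here, in a functional assay (plasma) with Oryctolagus cuniculus as the target (on this read-out lower numbers stand for stronger inhibition and higher numbers for weaker inhibition), compound 1 `Cc1nc2cnccc2n1CC1CCN(C(=O)CC(C)(C)c2ccccc2)CC1` gives 6.7 nM and stands lowest of the two numbers known, while compound 2 `Cc1nc2cnccc2n1CC1CCN(C(=O)C=C(c2ccccc2)c2ccccc2)CC1` gives 240 nM and lies higher by a margin beyond the usual scatter. Compound 3 `Cc1nc2cnccc2n1CC1CCN(C(=O)CN(C)c2ccccc2)CC1` keeps the core of compound 1 and carries methyl(phenyl)amino in place of 1-methyl-1-phenylethyl on a saturated chain carbon bound to a carbonyl carbon. For the measured compounds named here, no measured pair shows this exchange, so the expectation is a loose one. With compound 1 at 6.7 nM as the lower of the two numbers, the change is expected to raise the number in this assay rather than lower it. The expected step of a 7.5-fold higher number from compound 1 to compound 3 (0.87 log units; beyond the scatter) is an estimated moderate rise beyond the scatter. For compound 3 the estimated value is 50 nM with 9 nM to 300 nM as its expected range.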

Compound 3, half-maximal inhibitory concentration: 23 nM
Estimate against measurement, compound 3: 2.2-fold (0.34 log units) above; low and high end bracket the measured number.
By their numbers in this assay, from the lowest: compound 1; then compound 3; then compound 2.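

In (this assay), methyl(phenyl)amino in place of 1-methyl-1-phenylethyl on a saturated chain carbon bound to a carbonyl carbon brings a modest loss of inhibition (a 3.4-fold higher number from compound 1 to compound 3 (0.54 log units; beyond the scatter)). This first measured exchange at this position shows that the nanomolar inhibition of compound 1 largely survives when the entering group has one nitrogen, one hydrogen-bond acceptor and one heavy atom fewer, with compound 3 at (23 nM). No measurement on hand gives a reason for the rise.

The compounds shown leave open whether the phenyl ring itself is needed at this position, since a cyclohexyl ring or a dimethylamino group could behave differently. They also leave open what the methyl on the nitrogen of methyl(phenyl)amino contributes, which a phenylamino group would test.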